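Bromo on the 2,3-dihydro-1H-indol-1-yl group: working notes

This account rests on a few compounds, and the source may have more. Where it says the series, first, only, none or still open, it means among the compounds named here.

- compound 1 `COc1ccc(CN(C(=O)CSC(=S)N2CCCC2)c2cc(OC)c(OC)c(OC)c2)cc1` gives 4970 nM in a functional assay on HCT-116 cells (Homo sapiens) for inhibition, read by CCK-8 assay, with a stated time of 48 h; a lower number here means a stronger inhibitor, a higher number a weaker inhibitor
- compound 2 `COc1ccc(CN(C(=O)CSC(=S)N2CCc3ccccc32)c2cc(OC)c(OC)c(OC)c2)cc1` gives 7710 nM in this assay

On these numbers, compound 2 stands within the scatter of compound 1, so the pair shows no clear order. Compound 3 `COc1ccc(CN(C(=O)CSC(=S)N2CCc3cc(Br)ccc32)c2cc(OC)c(OC)c(OC)c2)cc1` is the next analogue. It carries bromo in place of hydrogen on an aromatic carbon and so has 5-bromo-2,3-dihydro-1H-indol-1-yl where compound 2 has 2,3-dihydro-1H-indol-1-yl.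

Going by the values given here, only one measured step bears on this change, and a 1.6-fold higher number from compound 1 to compound 2 (0.19 log units; within the scatter) stays within the scatter as 2,3-dihydro-1H-indol-1-yl takes the place of pyrrolidin-1-yl on a thiocarbonyl carbon. That step swaps the whole group on the thiocarbonyl carbon. Among the compounds with values here, no measured compound carries a bromo, so the data give no direct size for this change and the range must stay wide.

The expected move is a 1.4-fold lower number from compound 2 to compound 3 (0.15 log units; within the scatter) and no step beyond the scatter is expected in this assay for this change. Compound 3 is estimated at 5500 nM within an expected range of 1800 nM to 14000 nM for this measurement.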

Compound 3, half-maximal inhibitory concentration: 8060 nM
Estimate against measurement, compound 3: 1.5-fold (0.17 log units) below; the range from low to high includes it.
By their numbers in this assay, from the lowest: compounds 1, 2 and 3 (each within the scatter of the next).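

In this assay, going by these compounds alone, the first direct reading of bromo in place of hydrogen on this aromatic carbon is a 1.0-fold higher number from compound 2 to compound 3 (0.02 log units; within the scatter) and so gives no size for the change beyond the scatter: at this position, the one added heavy atom leaves the 5-bromo-2,3-dihydro-1H-indol-1-yl group indistinguishable from the 2,3-dihydro-1H-indol-1-yl group. Against the pyrrolidin-1-yl group on the thiocarbonyl carbon, the brominated group gives a 1.6-fold higher number from compound 1 to compound 3 (0.21 log units; within the scatter) and so also stays within the scatter, which means all three groups on that carbon sit in one band with no order among them. No measurement here offers a reason for this flat reading.

Open, from the compounds shown here alone, is whether any other group on this same aromatic carbon, such as an amine or a carboxylic acid, would move the number beyond the scatter, or whether the band holds for these as it does for bromo. Also open, going by these compounds, is whether bromo on another carbon of this six-membered aromatic ring reads the same, and whether an open chain such as diethylamino on the thiocarbonyl carbon stays within this band.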